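Ethoxycarbonyl to Hydroxymethyl: Expecting Compound 4

The source may report more compounds than this note shows. Statements on the series, on what has been measured and on what is new or still open speak of the compounds shown alone.

Compound 1, `C/C=C/C(=O)Nc1ccc(Cn2nc(-c3ccc(Oc4ccccc4)cc3)cc2C(=O)OCC)cc1`: in a functional assay on Z-138 cells (Homo sapiens) for inhibition, read by luminescence and CellTiter-Glo, with a stated time of 72 h (on this read-out lower numbers stand for stronger inhibition and higher numbers for weaker inhibition), compound 1 gives only a limit, > 60000 nM.
Compound 2, `C/C=C/C(=O)Nc1ccc(Cn2nc(-c3ccc(Oc4ccccc4)cc3)cc2CO)cc1`: in this assay compound 2 gives 54500 nM.
Compound 3, `C=CC(=O)Nc1cccc(Cn2nc(-c3ccc(Oc4ccccc4)cc3)cc2C(=O)OCC)c1`: in this assay compound 3 gives 7800 nM.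

The value of compound 1 is a limit of the assay and not a number, (the limit of > 60000 nM in this assay, at which 1 of the 3 values shown sits). Compound 2 differs from compound 1 by hydroxymethyl in place of ethoxycarbonyl on an aromatic carbon, and this change gave an at least 1.1-fold lower number from compound 1 to compound 2 (0.04 log units; that floor lies within the scatter). For the measured compounds named here, compound 3 differs from compound 1 in its core: 3-((vinylcarbonyl)amino)phenyl in place of 4-(((prop-1-en-1-yl)carbonyl)amino)phenyl on a saturated chain carbon bound to an aromatic nitrogen; the change gave an at least 7.6-fold lower number from compound 1 to compound 3 (0.88 log units; beyond the scatter), so compound 3 holds the lowest of the two numbers so far.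

Compound 4, `C=CC(=O)Nc1cccc(Cn2nc(-c3ccc(Oc4ccccc4)cc3)cc2CO)c1`, is not yet measured. It differs from compound 3 by hydroxymethyl in place of ethoxycarbonyl on an aromatic carbon, which is the same change as that made from compound 1 to compound 2, at the same place, occurring twice among the compounds here. Because the earlier step was an at least 1.1-fold lower number from compound 1 to compound 2 (0.04 log units; that floor lies within the scatter), the expected step is a 1.2-fold lower number from compound 3 to compound 4 (0.08 log units; within the scatter), roughly flat. Compound 4 is therefore expected to give about 6500 nM, between 2500 nM and 18000 nM.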

Compound 4, half-maximal inhibitory concentration: 6000 nM
For compound 4 the middle estimate is 1.1-fold (0.03 log units) above the measured one; measured number inside the range.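

In this assay, hydroxymethyl in place of ethoxycarbonyl on the core of compound 3 gave a 1.3-fold lower number from compound 3 to compound 4 (0.11 log units; within the scatter), so on this core the two numbers cannot be told apart. Set beside the earlier case, the two steps read as follows: the same change on two cores in this assay, an at least 1.1-fold lower number (0.04 log units; that floor lies within the scatter) from compound 1 to compound 2 and a 1.3-fold lower number (0.11 log units; within the scatter) from compound 3 to compound 4; the limit leaves it open whether they differ. Compound 1 gives only a limit, > 60000 nM, so the compounds show no sign that the change behaves differently on the two cores, but they do not show that it behaves the same.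

On these data alone, whether a carboxylic acid, an amine or a longer chain on this aromatic carbon would give a number different from that of compound 4 remains open. Also open, as far as these compounds go, is how the change reads on any further core, since it appears here only in two pairs, and only one of these gives a number at both ends.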